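This account rests on a few compounds, and the source may have more. Where it says the series, first, only, none or still open, it means among the compounds named here.

Values measured so far in an ADME assay for lipophilicity; on this read-out higher numbers stand for higher lipophilicity and lower numbers for lower lipophilicity:

compound 1 `Cc1cc(=O)c(O)c(C)o1` gives 0.44
compound 2 `CCc1oc(C)cc(=O)c1O` gives 1.07
compound 3 `CCCc1oc(C)cc(=O)c1O` gives 1.4

Compound 3 stands highest of the three in this assay at 1.4, with compound 2 nearest at 1.07 and compound 1 furthest at 0.44. Compound 4 `CCCCc1oc(C)cc(=O)c1O` has yet to be measured. It differs from compound 3 by a single change, (methyl in place of hydrogen on a saturated chain carbon, three bonds along the chain from an aromatic carbon), which is methyl in place of hydrogen on a saturated chain carbon, three bonds along the chain from an aromatic carbon. Cut one bond further out, the same change reads propyl to butyl.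

Two measured steps of this kind bear on it. In the first, a number 0.63 log units higher from compound 1 to compound 2 (beyond the scatter), methyl replaced hydrogen on a saturated chain carbon bound to an aromatic carbon. In the second, a number 0.33 log units higher from compound 2 to compound 3 (beyond the scatter), methyl replaced hydrogen two bonds along the chain from an aromatic carbon. Together they make up a number 0.96 log units higher from compound 1 to compound 3 (beyond the scatter) (also modest). Going by the values given here, no measured compound shows what happens three bonds along the chain, so the expectation is an extrapolation from these steps. A further modest rise of similar size is expected, estimated as a number 0.45 log units higher from compound 3 to compound 4 (beyond the scatter), and this lies beyond the scatter. For compound 4 the estimated value is 1.85, with an expected range from 1.6 to 2.2 (still to be tested by measurement).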

Compound 4, distribution coefficient: 1.92
For compound 4 the middle estimate is 0.07 log units below the measured one; the measured number falls inside the stated range.
By their numbers in this assay, from the lowest: compound 1; then compound 2; then compound 3; then compound 4.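

Three bonds along the chain from an aromatic carbon, methyl in place of hydrogen still raises the number in this assay, giving a number 0.52 log units higher from compound 3 to compound 4 (beyond the scatter), and this step agrees with the same change made on the shorter chain: the same change on two cores in this assay, a number 0.63 log units higher (beyond the scatter) from compound 1 to compound 2 and a number 0.52 log units higher (beyond the scatter) from compound 3 to compound 4, 0.11 log units apart, within the scatter of two such steps. Ethyl in place of hydrogen, two bonds along the chain from an aromatic carbon, gives a number 0.85 log units higher from compound 2 to compound 4 (beyond the scatter), and this too agrees with the ethyl step on a saturated chain carbon bound to an aromatic carbon: the same change on two cores in this assay, a number 0.96 log units higher (beyond the scatter) from compound 1 to compound 3 and a number 0.85 log units higher (beyond the scatter) from compound 2 to compound 4, 0.11 log units apart, within the scatter of two such steps. Across the whole series the rise comes to a number 1.48 log units higher from compound 1 to compound 4 (beyond the scatter), the only step in the series so far that counts as large, and it leaves compound 4 highest of the four, beyond the scatter from each of the others.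

The compounds shown leave open whether the rise continues with a longer chain such as pentyl, or how a branched chain such as isobutyl would compare with the butyl of compound 4. They also leave open how an amine or a carboxylic acid at the end of the chain would read in this assay.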